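Thiophene for methylsulfanylphenyl in the enone sulfone series

The compounds below may be only part of what the source reports. "The series", "measured", "known", "first", "only" and "open" are said of these compounds alone.

Compound 1 `CSc1ccc(/C=C(\C(=O)c2ccc(Cl)cc2)S(=O)(=O)Cc2ccc(C)cc2)cc1` gives 10000 nM in a functional assay on DU-145 cells (Homo sapiens) for inhibition, read by trypan blue exclusion, with a stated time of 96 h; on this read-out lower numbers stand for stronger inhibition of growth and higher numbers for weaker inhibition of growth. Compound 2 `COc1ccc(/C=C(\C(=O)c2ccc(Br)cc2)S(=O)(=O)c2ccc(Br)cc2)c(F)c1` gives 10000 nM and compound 3 `CSc1ccc(/C=C(\C(=O)c2ccc(Br)cc2)S(=O)(=O)Cc2ccc(C)cc2)cc1` gives 10000 nM in this assay, so compound 1 stands level with both at the digits shown. Among the compounds with values here, the only single-point step measured, no change at the digits printed from compound 1 to compound 3 (within the scatter), lies within the scatter. Compound 4 `Cc1ccc(CS(=O)(=O)/C(=C/c2ccc(C)s2)C(=O)c2ccc(Cl)cc2)cc1` differs from compound 1 by 5-methylthiophen-2-yl in place of 4-(methylsulfanyl)phenyl on a double-bonded chain carbon bound to a double-bonded chain carbon. Within the data shown here, no measured step bears directly on this exchange; the one step available concerns a halogen and was flat. With three compounds level and no step beyond the scatter, the expected change no change at the digits printed from compound 1 to compound 4 (within the scatter) is none beyond the scatter. Compound 4 is therefore estimated at 10000 nM, with a range from 5000 nM to 20000 nM.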

Compound 4, concentration for 50% growth inhibition: 25000 nM
Compound 4: the middle estimate sits 2.5-fold (0.40 log units) below what was measured; the whole stated range lies below it.
By their numbers in this assay, from the lowest: compounds 1, 2 and 3 (each within the scatter of the next); then compound 4.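

In this assay, within the data shown here, this is the first exchange to move the number beyond the scatter (a 2.5-fold higher number from compound 1 to compound 4 (0.40 log units; beyond the scatter)), and it moves toward weaker inhibition of growth. On a double-bonded chain carbon bound to a double-bonded chain carbon, 5-methylthiophen-2-yl therefore does not hold the level of 4-(methylsulfanyl)phenyl, although the step is modest. No available evidence accounts for this shift. The compounds shown do not separate the contribution of the thiophene ring from that of its methyl group. Also open, going by these compounds, is how an unsubstituted thiophen-2-yl or a 4-aminophenyl would read at this position.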